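Amide-side replacement on the shared core

This account rests on a few compounds, and the source may have more. Where it says the series, first, only, none or still open, it means among the compounds named here.

Measured so far:
compound 1 `O=C([C@H]1CC2CCC1C2)N1CC(c2nc(-c3cccc(Cl)c3)no2)C1`: 74 nM
compound 2 `CC1CN(C(=O)N2CC(c3nc(-c4cccc(Cl)c4)no3)C2)CC(C)O1`: limit only

In an assay on HEK293 cells for positive allosteric modulation of metabotropic glutamate receptor 5 (Homo sapiens), read by FLIPR (a lower number here means that less compound is needed, a higher number that more compound is needed for the effect), compound 1 gives 74 nM. For compound 2 the assay reports only a limit, > 10000 nM. Compound 2 therefore sits at the limit of > 10000 nM in this assay, at which 1 of the 2 values shown sits. The step of an at least 130-fold higher number from compound 1 to compound 2 (2.13 log units; beyond the scatter) is the only measured one and is large. Compound 3 `O=C([C@@H]1CC2CCC1C2)N1CC(c2nc(-c3cccc(Cl)c3)no2)C1` reverses that exchange: a group of 7 heavy atoms (7 carbon; 2 five-membered non-aromatic rings of carbon only) in place of a group of 8 heavy atoms (6 carbon, 1 nitrogen, 1 oxygen; one six-membered non-aromatic ring with 2 hetero atoms), on a carbonyl carbon. Compound 3 carries the same group as compound 1, differing only in the configuration of its defined stereocentre. Because the step of an at least 130-fold higher number from compound 1 to compound 2 (2.13 log units; beyond the scatter) was large and upward, the reverse change is expected to lower the number strongly. Compound 3 is estimated at 200 nM (range 40 nM to 2000 nM). The expected step is an at least 50-fold lower number from compound 2 to compound 3 (1.69 log units; beyond the scatter).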

Compound 3, half-maximal effective concentration: 98 nM
Compound 3: the middle estimate sits 2.0-fold (0.31 log units) above what was measured; the range from low to high includes it.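

In this assay, replacing 2,6-dimethylmorpholin-4-yl with the carbon-only group on the carbonyl carbon gives an at least 100-fold lower number from compound 2 to compound 3 (2.00 log units; beyond the scatter), so the second drawn configuration of that group also gives the low number. Configuration at this saturated ring carbon shows no effect beyond the scatter, with a 1.3-fold higher number from compound 1 to compound 3 (0.12 log units; within the scatter). This stereo comparison carries a qualification: the fact that one of compounds 1 and 3 is drawn with a defined configuration and the other without, at the place where they differ

On these data alone, whether a piperidin-1-yl or a cyclohexyl group on the carbonyl carbon would keep a low number remains open. Also open, as far as these compounds go, is whether the ring oxygen or the carbon-only rings decide the large step.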